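Vero cytotoxicity notes: oxadiazoline series, aryl exchange at saturated carbon

This account rests on a few compounds, and the source may have more. Where it says the series, first, only, none or still open, it means among the compounds named here.

Measured so far:
compound 1, `CC(=O)N1N=C(c2ccc(-n3c(C)ccc3C)cc2)OC1c1ccccc1Cl`: 201000 nM
compound 2, `Cc1ccc(C)n1-c1ccc(C(=O)N/N=C/c2ccccc2Cl)cc1`: "not determined" (no result reported)
compound 3, `Cc1ccc(C)n1-c1ccc(C(=O)N/N=C/c2ccc(N(C)C)cc2)cc1`: "not determined" (no result reported)

Among the measured compounds shown here, compound 1 is the only member of the series with a number in an ADME assay on Vero cells (Chlorocebus sabaeus) for cytotoxicity, read by MTT assay, with a stated time of 72 h; on this read-out lower numbers stand for stronger inhibition and higher numbers for weaker inhibition; in this assay compound 1 gives 201000 nM, while compound 2 is recorded as "not determined" (no result reported) and compound 3 as "not determined" (no result reported), so no ordering among the three can be drawn. Compound 4, `CC(=O)N1N=C(c2ccc(-n3c(C)ccc3C)cc2)OC1c1cccc([N+](=O)[O-])c1`, has not yet been measured. It differs from compound 1 in one place: 3-nitrophenyl in place of 2-chlorophenyl on a saturated ring carbon. For the measured compounds named here, no step between two measured compounds is available to calibrate this change. With only a single measured point, the expectation is that compound 4 stays close to compound 1 on this assay, with no step beyond the usual scatter. The expected step of a 1.1-fold lower number from compound 1 to compound 4 (0.02 log units; within the scatter) is therefore taken as flat. Compound 4 is estimated at 190000 nM, with a range from 90000 nM to 400000 nM, and there is a fair chance the assay returns only a limit rather than a number.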

Compound 4, half-maximal inhibitory concentration: 188000 nM
Beside the measured number, compound 4's estimate is 1.0-fold (0.00 log units) above it, within the range that was stated.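

Among the compounds shown here, this is the first step that can be read at this position. In this assay, 3-nitrophenyl in place of 2-chlorophenyl on the saturated ring carbon gives a 1.1-fold lower number from compound 1 to compound 4 (0.03 log units; within the scatter), so the two compounds cannot be told apart, even though the entering group is larger by heavy-atom count and carries hydrogen-bond acceptors that the leaving group lacks. No measured property is available to bear on this result.

This single pair does not show whether the same holds for a carboxylic acid on the phenyl ring, or for an open alkyl chain in place of the aryl group on this carbon. Also open, going by these compounds, is how a longer acyl chain in place of the acetyl group would read on the core of compound 1.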